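Replacing 3,4-dihydroxyphenyl with 4-methoxyphenyl in compound 3

The source may report more compounds than this note shows. Statements on the series, on what has been measured and on what is new or still open speak of the compounds shown alone.

Compound 1 `COc1ccc(C2=C(c3ccc(SC)cc3)CC3CCCN3C2=O)cc1O` gives 20000 nM
Compound 2 `CSc1ccc(C2=C(c3ccc(F)c(F)c3)C(=O)N3CCCC3C2)cc1` gives 200 nM
Compound 3 `CSc1ccc(C2=C(c3ccc(O)c(O)c3)C(=O)N3CCCC3C2)cc1` gives 50000 nM

In a functional assay on SW-620 cells (Homo sapiens) for cytotoxicity (on this read-out lower numbers stand for stronger inhibition of growth and higher numbers for weaker inhibition of growth), compound 3 stands highest of the three. Compound 4 `COc1ccc(C2=C(c3ccc(SC)cc3)CC3CCCN3C2=O)cc1` carries 4-methoxyphenyl in place of 3,4-dihydroxyphenyl on a double-bonded ring carbon, with the counted difference 4-methoxyphenyl in place of 3,4-dihydroxyphenyl on a double-bonded ring carbon as its full description. Among the compounds with values here, three measured steps bear on this change. The step of a 250-fold higher number from compound 2 to compound 3 (2.40 log units; beyond the scatter) is large, as is the step of a 100-fold lower number from compound 1 to compound 2 (2.00 log units; beyond the scatter) on the same ring carbon. The step of a 2.5-fold higher number from compound 1 to compound 3 (0.40 log units; beyond the scatter) is modest. Within the data shown here, no measured compound carries 4-methoxyphenyl itself, so a large step to a lower number is expected, estimated as a 25-fold lower number from compound 3 to compound 4 (1.40 log units; beyond the scatter) in this comparison. For compound 4 the estimate is 2000 nM with an expected range of 200 nM to 20000 nM on this read-out.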

Compound 4, concentration for 50% growth inhibition: 3000 nM
Compound 4: the middle estimate sits 1.5-fold (0.18 log units) below what was measured, within the range that was stated.
By their numbers in this assay, from the lowest: compound 2; then compound 4; then compound 1; then compound 3.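

In this assay, taking the single hydroxy off the aryl group on this double-bonded ring carbon gives a 6.7-fold lower number from compound 1 to compound 4 (0.82 log units; beyond the scatter), and the full change from 3,4-dihydroxyphenyl gives a 17-fold lower number from compound 3 to compound 4 (1.22 log units; beyond the scatter), so among these compounds the two carrying a hydroxy on this ring give the highest numbers. Having no hydroxy is still not enough to match 3,4-difluorophenyl, as 4-methoxyphenyl gives a 15-fold higher number from compound 2 to compound 4 (1.18 log units; beyond the scatter). No measurement shown explains these steps. The compounds shown leave open whether a 4-fluorophenyl or a 4-aminophenyl group on this ring carbon would come closer to compound 2.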